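A few compounds are considered here, and "the series" means these few. Any claim that something is new, unique, unknown or untested is made for them only; others in the source may bear on it.

In a functional assay on K562 cells (Homo sapiens) for antiproliferative activity, read by MTT assay, with a stated time of 24 h (on this read-out lower numbers stand for stronger inhibition and higher numbers for weaker inhibition), compound 3 `COc1ccc(C(=O)/C=C/c2ccccc2Cl)c2c1C=CC(C)(C)O2` gives the limit > 10000 nM and no number. Compound 1 `COc1ccc(C(=O)/C=C/c2ccc(F)cc2)c2c1C=CC(C)(C)O2` also gives only a limit, > 10000 nM in this assay as well. Compound 2 `COc1ccc(C(=O)/C=C/c2ccc(Br)cc2)c2c1C=CC(C)(C)O2` likewise gives the limit > 10000 nM and no number. What the three share is the limit of > 10000 nM in this assay, at which 3 of the 3 values shown sit, and nothing finer. Compound 4 `COc1ccc(C(=O)/C=C/c2cc(Cl)ccc2O)c2c1C=CC(C)(C)O2` carries 5-chloro-2-hydroxyphenyl in place of 2-chlorophenyl on a double-bonded chain carbon bound to a double-bonded chain carbon, and the count is 5-chloro-2-hydroxyphenyl in place of 2-chlorophenyl on a double-bonded chain carbon bound to a double-bonded chain carbon for that exchange. The measured steps that bear on it are a step that the two limits leave unreadable from compound 1 to compound 3 and a step that the two limits leave unreadable from compound 2 to compound 3 together with a step that the two limits leave unreadable from compound 1 to compound 2 and none has a readable size. Among the compounds with values here, none of the measured compounds carries a hydrogen-bond donor, so no step of known size or direction can be carried over. The expected change in this assay is therefore none beyond the scatter, and the estimated step is a step that the limit leaves unreadable from compound 3 to compound 4 in this reading. For compound 4 the estimate is 15000 nM with an expected range from 5000 nM to 40000 nM and a good chance of another limit.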

Compound 4, half-maximal inhibitory concentration: 5510 nM
Compound 4: middle estimate off by 2.7-fold (0.43 log units), on the high side; low and high end bracket the measured number.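

In this assay, compound 4 alone among the compounds shown gives a number rather than a limit, so 5-chloro-2-hydroxyphenyl at this place on the chain is the first group here to give a readable value. The exchange from 2-chlorophenyl gives an at least 1.8-fold lower number from compound 3 to compound 4 (0.25 log units; that floor lies within the scatter), the exchange from 4-bromophenyl gives an at least 1.8-fold lower number from compound 2 to compound 4 (0.25 log units; that floor lies within the scatter), and the exchange from 4-fluorophenyl gives an at least 1.8-fold lower number from compound 1 to compound 4 (0.25 log units; that floor lies within the scatter). The steps among the other compounds cannot be read, and those compounds share one limit: the limit of > 10000 nM in this assay, at which 3 of the 4 values shown sit.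

Going by these compounds, the true size of these steps stays open, and so does the question of whether the hydroxy group or the different chloro placement in 5-chloro-2-hydroxyphenyl accounts for the readable value. On these data alone, how a methoxy group or an amine in place of that hydroxy group would read in this assay also remains open.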